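Moving the fluorine on a fluorophenyl thiosemicarbazone

The source may hold more compounds than are shown below. What is called first, only, known or untested is meant among the compounds shown, and "the series" means these compounds.

compound 1 `O=C1Nc2ccc(F)cc2/C1=N/NC(=S)Nc1ccccc1`: 70%
compound 2 `O=C1Nc2ccc(F)cc2/C1=N/NC(=S)Nc1ccc(OC(F)(F)F)cc1`: 35%
compound 3 `O=C1Nc2ccc(F)cc2/C1=N/NC(=S)Nc1ccccc1F`: 35%

These values come from a functional assay on the whole organism for inhibition, with Lemna aequinoctialis as the target, with a stated time of 7 days, tested at 500 ug/mL; a lower number here means less inhibition of growth, a higher number more inhibition of growth at the concentration tested. Compound 3 gives 35%, level with compound 2, and compound 1 stands well above both. Compound 4 `O=C1Nc2ccc(F)cc2/C1=N/NC(=S)Nc1ccc(F)cc1` has the same atoms as compound 3, joined differently: 4-fluorophenyl in place of 2-fluorophenyl on an amide-type nitrogen. Among the compounds with values here, no measured step moves a group in this way, so only two steps bear on it. Fluoro in place of hydrogen gave a number 35 percentage points lower from compound 1 to compound 3 (beyond the scatter), and trifluoromethoxy in place of hydrogen gave a number 35 percentage points lower from compound 1 to compound 2 (beyond the scatter). Both are large and equal in size, so the expectation is that compound 4 stays close to compound 3 in this assay. The expected change is a number 5 percentage points higher from compound 3 to compound 4 (within the scatter), none beyond the scatter. Compound 4 is estimated at 40%, with an expected range of 20% to 65%.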

Compound 4, percent growth inhibition at one concentration: 35%
The estimate for compound 4 lay 5 percentage points above the measured number; low and high end bracket the measured number.
By their numbers in this assay, from the lowest: compounds 2, 3 and 4 (each within the scatter of the next); then compound 1.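

In this assay, 4-fluorophenyl in place of 2-fluorophenyl on the amide-type nitrogen gives no change at the digits printed from compound 3 to compound 4 (within the scatter) and so the two fluorine placements cannot be told apart. Fluoro in place of trifluoromethoxy gives no change at the digits printed from compound 2 to compound 4 (within the scatter) and shows that this position does not separate these two groups either. Fluoro in place of hydrogen gives a number 35 percentage points lower from compound 1 to compound 4 (beyond the scatter) and thus all three substituted compounds stand apart from compound 1. No measurement offered here explains this shared level. On these data alone, whether an amine or a carboxylic acid on this phenyl ring would share it remains open.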